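The source may hold more compounds than are shown below. What is called first, only, known or untested is meant among the compounds shown, and "the series" means these compounds.

Compound 1 `O=S(=O)(NCCCCCCNCc1ccc(Br)cc1)c1ccc2c(c1)OCC2`: 13000 nM
Compound 2 `O=S(=O)(NCCCCCCNCc1ccc(Br)cc1)c1c(Cl)cccc1Cl`: 14700 nM

Within the data shown here, in a functional assay on MIA PaCa-2 cells (Homo sapiens) for inhibition, read by MTT assay, with a stated time of 72 h (a lower number here means a stronger inhibitor of growth, a higher number a weaker inhibitor of growth), compound 2 gives 14700 nM, and its only neighbour differs from it within the scatter, as a 1.1-fold higher number from compound 1 to compound 2 (0.05 log units; within the scatter) shows. Compound 3 `O=[N+]([O-])c1ccccc1S(=O)(=O)NCCCCCCNCc1ccc(Br)cc1` differs from compound 2 by 2-nitrophenyl in place of 2,6-dichlorophenyl on a sulfonyl sulfur. Among the measured compounds shown here, the one measured step that bears on this, an exchange of the ring on the sulfonyl sulfur, stayed within the scatter, so a similar exchange in compound 3 is expected to move this assay little. Compound 3 is therefore estimated at 14000 nM, within 5000 nM to 40000 nM, an expected step of a 1.1-fold lower number from compound 2 to compound 3 (0.02 log units; within the scatter).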

Compound 3, concentration for 50% growth inhibition: 11700 nM
Beside the measured number, compound 3's estimate is 1.2-fold (0.08 log units) above it, and the stated range covers the measured number.
By their numbers in this assay, from the lowest: compounds 3, 1 and 2 (each within the scatter of the next).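

In this assay, 2-nitrophenyl on the sulfonyl sulfur stays within the scatter of both earlier groups, 2,6-dichlorophenyl (a 1.3-fold lower number from compound 2 to compound 3 (0.10 log units; within the scatter)) and the ring of compound 1 (a 1.1-fold lower number from compound 1 to compound 3 (0.05 log units; within the scatter)). This position has now taken a third group, one carrying nitrogen and oxygen rather than chlorine, with no readable change in growth inhibition. No measured property explains why these numbers stay so close. Still open, from the compounds shown here alone, is whether a carboxylic acid or an amine on this ring would move the number. A longer chain on the sulfonamide nitrogen is equally untested among these compounds.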